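This account rests on a few compounds, and the source may have more. Where it says the series, first, only, none or still open, it means among the compounds named here.

Measured in an assay on CHO cells for antagonist activity at transient receptor potential cation channel subfamily V member 1 (Homo sapiens), read by FLIPR and calcium flux; on this read-out higher numbers stand for weaker inhibition and lower numbers for stronger inhibition:
compound 1 `Cc1nc(C(F)(F)F)ccc1CNC(=O)C(C)c1ccc(NS(C)(=O)=O)c(F)c1` gives 387 nM
compound 2 `CC(C(=O)NCc1ccc(C(F)(F)F)nc1C1=C[C@H](C)CCC1)c1ccc(NS(C)(=O)=O)c(F)c1` gives 0.1 nM

Within the data shown here, compound 2 stands at the lowest of the two numbers in this assay; its only neighbour is compound 1, and the single measured step, a 3900-fold lower number from compound 1 to compound 2 (3.59 log units; beyond the scatter), separates them by far more than the scatter. That step exchanged methyl for 3-methylcyclohex-1-en-1-yl on an aromatic carbon and is the sole indication of what a large group at this position does.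

Compound 3 `CC(C(=O)NCc1ccc(C(F)(F)F)nc1/C=C/C1CCCCC1)c1ccc(NS(C)(=O)=O)c(F)c1` is the next case:
2-cyclohexylethenyl in place of 3-methylcyclohex-1-en-1-yl on an aromatic carbon

Among the measured compounds shown here, no measured step tests this exchange directly. What the step from compound 1 bears out is that a large group at this aromatic carbon lowers the number strongly; compound 3 keeps a group of closely matched heavy-atom count, one six-membered non-aromatic ring and one double bond outside aromatic rings. The expectation in this assay is therefore a step no larger than a 3.0-fold higher number from compound 2 to compound 3 (0.48 log units; beyond the scatter), if anything towards a slightly higher number. Compound 3 is estimated at 0.3 nM, with a range from 0.05 nM to 2 nM.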

Compound 3, inhibition constant: 0.7 nM
Beside the measured number, compound 3's estimate is 2.3-fold (0.37 log units) below it, within the range that was stated.
By their numbers in this assay, from the lowest: compound 2; then compound 3; then compound 1.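

In this assay, exchanging 3-methylcyclohex-1-en-1-yl for 2-cyclohexylethenyl on this aromatic carbon gives a 7.0-fold higher number from compound 2 to compound 3 (0.85 log units; beyond the scatter) and so, although modest, the step shows that the read-out still separates two large groups that each hold one six-membered non-aromatic ring of carbon only and one double bond outside aromatic rings. Measured against the methyl group, 2-cyclohexylethenyl gives a 550-fold lower number from compound 1 to compound 3 (2.74 log units; beyond the scatter) as a large step, which means that the drop first seen with compound 2 is not confined to a single large group and holds for both large groups shown here. No supporting data bear on what lies behind the difference between these two groups.

Among these compounds, the single exchange changes the way the ring is attached, the ring methyl and the defined stereocentre together, so the share of each in the step remains unresolved. Also open, going by these compounds, is how this position responds to a saturated 2-cyclohexylethyl chain, a shorter ethyl group, or a large group carrying an amine or a carboxylic acid.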